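Pyrazolopyrimidinone amides: chlorophenyl isomer swap ahead of measurement

The source may report more compounds than this note shows. Statements on the series, on what has been measured and on what is new or still open speak of the compounds shown alone.

Two members of the series have been measured in a functional assay on HT-29 cells (Homo sapiens) for cytotoxicity, read by sulforhodamine B assay, with a stated time of 2 days, tested at 100 uM; on this read-out higher numbers stand for more inhibition at the one concentration tested (going by the name of the read-out) and lower numbers for less inhibition. Compound 1 `O=C(Nn1c(-c2cccc([N+](=O)[O-])c2)nc2c(-c3ccc(Cl)cc3)n[nH]c2c1=O)c1cccnc1` gives 15.1% in this assay. Compound 2 `O=C(Nn1c(-c2cccc([N+](=O)[O-])c2)nc2c(-c3cccc(Cl)c3)n[nH]c2c1=O)c1ccccc1` gives 89.8% in this assay, the higher of the two numbers; compound 1 lies a long way below it, beyond the usual scatter. Compound 1 and compound 2 differ in more than one place, so the two values cannot be assigned to a single change.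

Compound 3 `O=C(Nn1c(-c2cccc([N+](=O)[O-])c2)nc2c(-c3ccc(Cl)cc3)n[nH]c2c1=O)c1ccccc1` is not yet measured. Against compound 2 it carries one change: 4-chlorophenyl in place of 3-chlorophenyl on an aromatic carbon. The same 4-chlorophenyl group is present in compound 1, whose low value in this assay is the only hint available, though its amide also differs.

On that basis compound 3 is expected to fall below compound 2, with the step of a number 39.8 percentage points lower from compound 2 to compound 3 (beyond the scatter) likely beyond the scatter but of uncertain size. The estimate for compound 3 in this assay is 50%, within 15% to 88%.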

Compound 3, a percentage reported as inhibition, at one concentration (the size of the read-out at that concentration, not a potency): 87.8%
Compound 3: middle estimate off by 37.8 percentage points, on the low side; the range from low to high includes it.
By their numbers in this assay, from the lowest: compound 1; then compounds 3 and 2 (each within the scatter of the next).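

With phenyl on the carbonyl carbon, 4-chlorophenyl in place of 3-chlorophenyl on an aromatic carbon of the five-membered aromatic ring gives in this assay a number 2 percentage points lower from compound 2 to compound 3 (within the scatter), so the two chlorophenyl isomers cannot be told apart at this position. The low value of compound 1 does not go with the 4-chlorophenyl group: phenyl in place of pyridin-3-yl on the carbonyl carbon gives a number 72.7 percentage points higher from compound 1 to compound 3 (beyond the scatter), and this one change in the amide carries the large gap. Nothing available explains the gap from the pyridin-3-yl group.

Open, going by these compounds, is whether pyridin-3-yl on the carbonyl carbon has the same effect alongside 3-chlorophenyl. Also open, on these data alone, is how a plain phenyl or a methoxyphenyl at the chlorophenyl position, or an aminophenyl or a carboxylic acid on the amide phenyl, would read out.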